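The source may report more compounds than this note shows. Statements on the series, on what has been measured and on what is new or still open speak of the compounds shown alone.

Measured compounds:
- Compound 1, `Cc1nnc(-c2cccc(-c3ccc(C(=O)N(Cc4cccc(OCCCCCC(=O)O)c4)C(C)C)cc3)c2)o1`: in an ADME assay on Raji cells (Homo sapiens) for cytotoxicity, read by CellTiter-Glo and resazurin assay, with a stated time of 72 h (on this read-out lower numbers stand for an effect already at smaller amounts and higher numbers for an effect only at larger amounts of compound), compound 1 gives > 26000 nM, which is a limit of the assay rather than a number.
- Compound 2, `CCOC(=O)CCCCCOc1cccc(CN(C(=O)c2ccc(-c3cccc(OCC(C)C)c3)cc2)C(C)C)c1`: in this assay compound 2 gives > 26000 nM, again a limit of the assay.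
- Compound 3, `CCOC(=O)CCCCCOc1cccc(CN(C(=O)c2ccc(-c3cccc(OCc4ccccc4)c3)cc2)C(C)C)c1`: in this assay compound 3 gives > 26000 nM, also a limit of the assay.

Compound 3 therefore stands where every measured value stands: at the limit, with no number behind it, as the limit of > 26000 nM in this assay, at which 3 of the 3 values shown sit, shows for all three. Among the compounds with values here, the only measured step between neighbours, a step that the two limits leave unreadable from compound 2 to compound 3, cannot be read because both ends are limits, so its size is unknown.

Compound 4, `CCOC(=O)CCCCCOc1cccc(CN(C(=O)c2ccc(-c3cccc(-c4nnc(C)o4)c3)cc2)C(C)C)c1`, is reached from compound 3 by the change (5-methyl-1,3,4-oxadiazol-2-yl in place of benzyloxy on an aromatic carbon). Within the data shown here, no measured step gives a readable size for a change of this kind, and the one step that exists is unreadable. Compound 4 is therefore expected to behave like compound 3 and to remain at the limit in this assay, so the expected step of a number no higher from compound 3 to compound 4 (the limit leaves the size open) is none that can be read. The estimate for compound 4 in this assay is 26000 nM, with a range from 10000 nM to 80000 nM.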

Compound 4, half-maximal effective concentration: > 26000 nM
Compound 4: a limit, no number; the forecaster's own chance of this, stated with the estimate: 85%; the middle value sits exactly at the limit.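

The steps from compound 1, compound 2 and compound 3 to compound 4 cannot be read, because each compound gives a limit of the assay rather than a number: the limit of > 26000 nM in this assay, at which 4 of the 4 values shown sit.

The compounds shown leave open whether these four differ from one another at all in this assay, and what size any of these changes has.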